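A few compounds are considered here, and "the series" means these few. Any claim that something is new, unique, unknown or untested is made for them only; others in the source may bear on it.

In a functional assay on U-251 cells (Homo sapiens) for antiproliferative activity, read by MTT assay, with a stated time of 48 h (on this read-out lower numbers stand for stronger inhibition and higher numbers for weaker inhibition), compound 1 `COc1cc(-c2cccc3nc(-c4ccccc4)oc23)cc(OC)c1OC` gives 3500 nM. Compound 2 `COc1cccc(-c2nc3cccc(-c4cc(OC)c(OC)c(OC)c4)c3o2)c1` reaches only a limit, > 25000 nM. Compound 3 `COc1cc(-c2cccc3nc(-c4ccc(Br)cc4)oc23)cc(OC)c1OC` also reaches only a limit, > 25000 nM. Compound 2 therefore stands at the limit of > 25000 nM in this assay, at which 2 of the 3 values shown sit. Compound 4 `COc1cc(-c2cccc3nc(-c4cccc(Cl)c4)oc23)cc(OC)c1OC` has chloro in place of methoxy on an aromatic carbon. Among the measured compounds shown here, two measured steps bear on this change, both beyond the scatter: an at least 7.1-fold higher number from compound 1 to compound 2 (0.85 log units; beyond the scatter) with methoxy in place of hydrogen, and an at least 7.1-fold higher number from compound 1 to compound 3 (0.85 log units; beyond the scatter) with bromo in place of hydrogen. Compound 4 likewise carries a substituent where compound 1 has hydrogen, so only a partial recovery is expected in this assay. The expected change, toward a lower number, is an at least 1.6-fold lower number from compound 2 to compound 4 (0.22 log units; that floor lies within the scatter). For compound 4 the estimate is 15000 nM, with an expected range of 5000 nM to 40000 nM.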

Compound 4, half-maximal inhibitory concentration: 18500 nM
The estimate for compound 4 lay 1.2-fold (0.09 log units) below the measured number, within the range that was stated.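

In this assay, a substituent on this ring no longer means a reading at the limit, yet chloro in place of hydrogen still leaves a 5.3-fold higher number from compound 1 to compound 4 (0.72 log units; beyond the scatter). Against the two limit compounds the readings are an at least 1.3-fold lower number from compound 2 to compound 4 (0.13 log units; that floor lies within the scatter) and an at least 1.3-fold lower number from compound 3 to compound 4 (0.13 log units; that floor lies within the scatter), so neither floor establishes a gain. Compound 2 remains a limit and not a number: the limit of > 25000 nM in this assay, at which 2 of the 4 values shown sit.

From the compounds shown here alone, how an amine or a carboxylic acid would read in the place of chloro stays open. So does whether any group on this ring can match the hydrogen of compound 1.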